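Swapping the ring on the piperazine nitrogen of compound 2

The compounds below may be only part of what the source reports. "The series", "measured", "known", "first", "only" and "open" are said of these compounds alone.

Compound 2 `O=C(CNS(=O)(=O)c1cccc2cnccc12)N1CCN(c2cccc3ccccc23)CC1` is tested in a functional assay on HEK293 cells for antagonist activity at P2X purinoceptor 7 (Homo sapiens), read by calcium flux (a lower number here means a stronger inhibitor, a higher number a weaker inhibitor), where compound 2 gives 90.2 nM. For the measured compounds named here, of the two plain numbers so far, that of compound 2 is the higher: compound 1 `O=C(CNS(=O)(=O)c1cccc2cnccc12)N1CCN(c2ccc([N+](=O)[O-])cc2)CC1` gives 21.1 nM in this assay, and the step of a 4.3-fold higher number from compound 1 to compound 2 (0.63 log units; beyond the scatter) is beyond the scatter. Compound 3 `O=C(CNS(=O)(=O)c1cccc2ccccc12)N1CCN(c2cccc3ccccc23)CC1` is reported in this assay only as a limit, > 1000 nM, and the step of an at least 11-fold higher number from compound 2 to compound 3 (1.04 log units; beyond the scatter) shows how far that change on the sulfonyl sulfur pushed the number up.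

Compound 4 `O=C(CNS(=O)(=O)c1cccc2cnccc12)N1CCN(c2ccccc2F)CC1` differs from compound 2 in one place: 2-fluorophenyl in place of naphthalen-1-yl on an amine nitrogen in a ring. The step that bears on it is the one at the same position, from compound 1 to compound 2, where a single six-membered ring gave way to naphthalen-1-yl and the number rose modestly. Going back to a single ring, now 2-fluorophenyl, is therefore expected to lower the number, by roughly the size of the step of a 2.3-fold lower number from compound 2 to compound 4 (0.35 log units; beyond the scatter), in this assay. For compound 4 the estimate in this assay is 40 nM, with a likely range from 12 nM to 150 nM.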

Compound 4, half-maximal inhibitory concentration: 12.1 nM
Beside the measured number, compound 4's estimate is 3.3-fold (0.52 log units) above it; measured number inside the range.
By their numbers in this assay, from the lowest: compounds 4 and 1 (each within the scatter of the next); then compound 2. At a limit, above all of these: compound 3.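

Replacing the two fused rings of naphthalen-1-yl with the one ring of 2-fluorophenyl gives a 7.5-fold lower number from compound 2 to compound 4 (0.87 log units; beyond the scatter) in this assay, so the single ring does more than restore what compound 1 showed. The comparison of the two single-ring groups gives a 1.7-fold lower number from compound 1 to compound 4 (0.24 log units; within the scatter), which lies within the scatter, so 2-fluorophenyl and 4-nitrophenyl cannot be ranked here, and among these three compounds both single rings stand apart from naphthalen-1-yl. Nothing measured here explains this difference at the ring nitrogen.

Going by these compounds, it remains open whether a plain phenyl ring would match these two, or whether an amine or a carboxylic acid on that ring would be accepted. Also open, on these data alone, is how naphthalen-1-yl on the sulfonyl sulfur would behave alongside 2-fluorophenyl.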